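This account rests on a few compounds, and the source may have more. Where it says the series, first, only, none or still open, it means among the compounds named here.

In a functional assay on the whole organism with Mus musculus as the target, with a stated time of 20 min (a higher number here means that more compound is needed for the effect, a lower number that less compound is needed), three compounds have been measured so far:

Compound 1 `CC(C)S(=O)(=O)Nc1ccc(N(C)C(=O)c2ccccc2)cc1` gives 0.1 mg/kg.
Compound 2 `CC(=O)N[C@H]1CC[C@H](NS(=O)(=O)c2ccc(F)cc2)CC1` gives 0.01 mg/kg.
Compound 3 `CC(=O)N[C@H]1CC[C@@H](NS(=O)(=O)c2ccc(F)cc2)CC1` gives 10 mg/kg.

Compound 1 stands second highest of the three numbers: compound 2 gives a lower number and compound 3 a higher one. Among the compounds with values here, the only step measured between two compounds that differ in a single place is a 1000-fold higher number from compound 2 to compound 3 (3.00 log units; beyond the scatter), and it is ascribed to the fact that (the fact that compounds 2 and 3 differ only in the configuration as drawn); these two compounds share the same atoms and bonds and are mirror images of each other.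

Compound 4 `CC(C)S(=O)(=O)Nc1ccc(NC(=O)c2ccccc2)cc1` is not yet measured. It differs from compound 1 by hydrogen in place of methyl on an amide-type nitrogen. Within the data shown here, no measured step concerns such a change: the one step available is between mirror images, not between an amide-type nitrogen bearing a methyl and one bearing a hydrogen. There is therefore no basis in the data for expecting a move in either direction beyond the usual scatter, and the expectation has to be wide. The expected step is no change at the digits printed from compound 1 to compound 4 (within the scatter), that is, essentially no change from compound 1. Compound 4 is estimated at 0.1 mg/kg, with a range from 0.02 mg/kg to 0.6 mg/kg.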

Compound 4, minimum effective dose: 1 mg/kg
Compound 4: the middle estimate sits 10-fold (1.00 log units) below what was measured, outside the stated range (above it).
By their numbers in this assay, from the lowest: compound 2; then compound 1; then compound 4; then compound 3.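

Replacing methyl with hydrogen on the amide-type nitrogen, whose other neighbours are an aromatic carbon and a carbonyl carbon, gives a 10-fold higher number from compound 1 to compound 4 (1.00 log units; beyond the scatter) in this assay, so more compound is needed for the effect once the methyl is gone. Within the data shown here, this is the first measured step that swaps one group for another, and it shows that a single carbon at this position is enough to move the number beyond the scatter; the only earlier step, a 1000-fold higher number from compound 2 to compound 3 (3.00 log units; beyond the scatter), concerned configuration alone and could say nothing about this nitrogen. The one explanation at hand concerns mirror images and does not bear on this change, so the data give no reason for the size or direction of this step.

As far as these compounds go, whether the number would keep falling with ethyl or a longer chain on this nitrogen, or rise again, remains open, since the position is known only with methyl and with hydrogen. Also open, from the compounds shown here alone, is whether a methyl on an amide-type nitrogen would have a similar effect in the core of compound 2, which is a different series.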